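The source may report more compounds than this note shows. Statements on the series, on what has been measured and on what is new or still open speak of the compounds shown alone.

Measured so far in a functional assay on HeLa cells (Homo sapiens) for inhibition; a higher number here means a weaker inhibitor, a lower number a stronger inhibitor:
compound 1, `CC(=O)OC(C)n1cnc2c(S)nc(N)nc21`, gives 89000 nM
compound 2, `CC(=O)OCCOn1cnc2c(S)nc(N)nc21`, gives 5000 nM
compound 3, `CC(=O)OC(C)n1cnc2c(S)nc(F)nc21`, gives only a limit of the assay, > 500000 nM

Of the two plain numbers, compound 2 holds the lower one and compound 1 the higher, a gap that lies beyond the scatter. The two cores of compound 1 and compound 2 differ in more than one place; that difference is not broken down here.

Among the measured compounds shown here, the one change followed within a single core is fluoro in place of amino on an aromatic carbon. In this assay it gives an at least 5.6-fold higher number from compound 1 to compound 3 (0.74 log units; beyond the scatter). The size is known only as a lower bound because the limit of > 500000 nM in this assay, at which 1 of the 3 values shown sits, caps what compound 3 can show in this assay.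

Compound 4, `CC(=O)OCCOn1cnc2c(S)nc(F)nc21`, applies the same change to the core of compound 2: fluoro in place of amino on an aromatic carbon. The surroundings of the exchanged group are described word for word as for the change from compound 1 to compound 3, so this is the same change on a different core.

The step expected in this assay is a 12-fold higher number from compound 2 to compound 4 (1.08 log units; beyond the scatter), resting on an at least 5.6-fold higher number from compound 1 to compound 3 (0.74 log units; beyond the scatter) and on the fact that this earlier step was itself cut off by a limit. Compound 4 is therefore expected to come out at about 60000 nM, most probably somewhere from 15000 nM to 300000 nM, with a real chance that only a limit is reported.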

Compound 4, half-maximal inhibitory concentration: > 500000 nM
Compound 4: only a limit was reported; the forecaster's own chance of this, stated with the estimate: 25%; middle value at least 8.3-fold (0.92 log units) away from the limit.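

In this assay, fluoro in place of amino on an aromatic carbon again moves the number up on the second core, giving an at least 100-fold higher number from compound 2 to compound 4 (2.00 log units; beyond the scatter). For compound 4 the result is only a limit of the assay, > 500000 nM. The direction of the change therefore carries over between the two cores shown, with amino the better group on both, but its size does not transfer as a figure, since each step is known only as a lower bound and no difference between the cores can be claimed: the same change on two cores in this assay, an at least 5.6-fold higher number (0.74 log units; beyond the scatter) from compound 1 to compound 3 and an at least 100-fold higher number (2.00 log units; beyond the scatter) from compound 2 to compound 4; the limit leaves it open whether they differ

On these data alone, compound 3 and compound 4 both end at a limit, so the two fluoro compounds cannot be ranked against each other, and what the side chain contributes without the amino group remains unknown. Open as well is whether amino is specifically required at this place or whether a methylamino group, a chloro group or a plain hydrogen would bring a measurable number, which would allow the change to be compared across the two cores with actual values at both ends.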